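Swapping pyrrolidin-1-yl for thiomorpholin-4-yl on a carbonyl carbon

The source may hold more compounds than are shown below. What is called first, only, known or untested is meant among the compounds shown, and "the series" means these compounds.

In an in vivo functional assay on the whole organism for inhibition, with Rattus norvegicus as the target (on this read-out higher numbers stand for an effect only at larger amounts of compound and lower numbers for an effect already at smaller amounts), compound 1 `CCCCc1nc(CCC)c(CCC(=O)OCC)c(=O)n1Cc1ccc(-c2ccccc2-c2nnn[nH]2)cc1` is reported as "not determined" (no result reported) and compound 2 `CCCc1nc(C)c(CC(=O)N(CC)CC)c(=O)n1Cc1ccc(-c2ccccc2-c2nnn[nH]2)cc1` as "not determined" (no result reported) so neither offers a number for comparison. Among the compounds with values here, compound 3 `CCCCc1nc(C)c(CC(=O)N2CCCC2)c(=O)n1Cc1ccc(-c2ccccc2-c2nnn[nH]2)cc1` gives 0.056 mg/kg and this is the only number available, which means it cannot yet be ranked against anything.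

Compound 4 `CCCCc1nc(C)c(CC(=O)N2CCSCC2)c(=O)n1Cc1ccc(-c2ccccc2-c2nnn[nH]2)cc1` differs from compound 3 in one place, with thiomorpholin-4-yl in place of pyrrolidin-1-yl on a carbonyl carbon. Within the data shown here, no measured pair in this set shows what a change of this kind does, so any forecast is uncertain. With only compound 3 at 0.056 mg/kg as an anchor, the expectation is a small move in this assay towards larger doses, perhaps little beyond the scatter of repeated measurements. The estimated change is a 1.8-fold higher number from compound 3 to compound 4 (0.25 log units; within the scatter) and a shift in the other direction would not be surprising. Compound 4 is estimated at 0.1 mg/kg with 0.03 mg/kg to 0.35 mg/kg as the expected range.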

Compound 4, dose for half-maximal effect: 0.038 mg/kg
For compound 4 the middle estimate is 2.6-fold (0.42 log units) above the measured one, and the stated range covers the measured number.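

In this assay, the position on the carbonyl carbon now has its first readable step, a 1.5-fold lower number from compound 3 to compound 4 (0.17 log units; within the scatter), so the two compounds cannot be told apart on this read-out. At least in this one pair, replacing the five-membered pyrrolidin-1-yl ring with the six-membered thiomorpholin-4-yl ring, which adds a sulfur atom and a hydrogen-bond acceptor, leaves the dose needed for half-maximal effect within ordinary experimental scatter. No supporting measurement here explains this outcome.

As far as these compounds go, a single pair cannot show how far this position accepts other rings, so it remains open whether morpholin-4-yl, with oxygen in place of sulfur, or piperidin-1-yl, with neither, would behave the same way. A carboxylic acid in place of the amide at this carbonyl carbon also remains an open question.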